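This account rests on a few compounds, and the source may have more. Where it says the series, first, only, none or still open, it means among the compounds named here.

In a functional assay on MDA-MB-231 cells (Homo sapiens) for cytotoxicity, read by MTT assay (on this read-out lower numbers stand for stronger inhibition and higher numbers for weaker inhibition), compound 1 (`CCn1cc(-c2nc3ccc([N+](=O)[O-])cc3o2)c(=O)c2cc(F)c(N3CCNC(C)C3)c(F)c21`) gives 2000 nM, compound 2 (`CCn1cc(C(=O)Nc2cccc([N+](=O)[O-])c2)c(=O)c2cc(F)c(N3CCNC(C)C3)c(F)c21`) gives 3250 nM and compound 3 (`CCn1cc(C(=O)Nc2ccc(C)c([N+](=O)[O-])c2)c(=O)c2cc(F)c(N3CCNC(C)C3)c(F)c21`) gives 4200 nM. Compound 2 therefore lies within the usual scatter of both other compounds. Compound 4 (`CCn1cc(C(=O)NCc2ccc(OC)cc2)c(=O)c2cc(F)c(N3CCNC(C)C3)c(F)c21`) carries 4-methoxybenzyl in place of 3-nitrophenyl on an amide-type nitrogen. Going by the values given here, the only measured step is a 1.3-fold higher number from compound 2 to compound 3 (0.11 log units; within the scatter), with methyl in place of hydrogen on an aromatic carbon. It does not test this replacement, so it bears only indirectly. No measurement shows a direction, so no step beyond the scatter is expected in this assay, though the uncertainty is wide. The expected change is a 1.1-fold higher number from compound 2 to compound 4 (0.03 log units; within the scatter). For compound 4, the estimated value is 3500 nM, with an expected range from 1200 nM to 10000 nM.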

Compound 4, half-maximal inhibitory concentration: 25300 nM
Beside the measured number, compound 4's estimate is 7.2-fold (0.86 log units) below it; measured number outside the range, above it.
By their numbers in this assay, from the lowest: compounds 1, 2 and 3 (each within the scatter of the next, the first and the last beyond it); then compound 4.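

Among the one-place steps shown, the group on this amide-type nitrogen is the first to move the result beyond the scatter in this assay: there is a 7.8-fold higher number from compound 2 to compound 4 (0.89 log units; beyond the scatter) and a 6.0-fold higher number from compound 3 to compound 4 (0.78 log units; beyond the scatter). Replacing either nitrophenyl group with 4-methoxybenzyl therefore weakens inhibition, whereas the added ring methyl gave no step beyond the scatter. No available evidence accounts for this loss. 4-Methoxybenzyl differs from 3-nitrophenyl in both its ring substituent and its carbon link to the nitrogen, and the compounds shown do not separate these two differences. On these data alone, how plain benzyl or 4-methoxyphenyl would read on this nitrogen stays open.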